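Cinnamyl to Carbamoylmethyl on a Nucleoside Core

This account rests on a few compounds, and the source may have more. Where it says the series, first, only, none or still open, it means among the compounds named here.

Measured compounds:
- compound 1, `Nc1nc(O)c2c(n1)n(C1OC(CO)[C@@H](O)[C@H]1O)c(=O)n2C/C=C/c1ccccc1`: 4 uM
- compound 2, `CCCn1c(=O)n(C2OC(COP(=O)(O)O)[C@@H](O)[C@H]2O)c2nc(N)nc(O)c21`: 82 uM
- compound 3, `C=CCn1c(=O)n([C@H]2CO[C@@H](CO)C2)c2nc(N)nc(O)c21`: 272 uM

Of the compounds shown here, three sharing a common core have been measured in a functional assay with Mus musculus as the target; a higher number here means that more compound is needed for the effect, a lower number that less compound is needed. Compound 1 gives 4 uM, the lowest of the three numbers. Compound 2 lies above it, and compound 3 lies furthest away; both of these gaps are beyond the usual scatter, so compound 1 is the most potent of the measured set.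

Compound 4, `NC(=O)Cn1c(=O)n(C2OC(CO)[C@@H](O)[C@H]2O)c2nc(N)nc(O)c21`, has not yet been measured in this assay. It differs from compound 1 in one place: carbamoyl in place of 2-phenylethenyl on a saturated chain carbon bound to an aromatic nitrogen. Within the data shown here, no pair of measured compounds differs in only one place, so no measured step gives a direct guide for this change. Among the measured compounds shown here, what the numbers show is that compound 1, the only compound carrying the 2-phenylethenyl group, gives 4 uM, while compound 2, which carries a shorter chain at the same position, gives 82 uM, and compound 3, which also carries a shorter chain there, gives 272 uM.

The step from compound 1 to compound 4 is expected to move the number upward, as a 15-fold higher number from compound 1 to compound 4 (1.18 log units; beyond the scatter). Compound 4 is estimated to give about 60 uM in this assay, within a range from 15 uM to 300 uM.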

Compound 4, concentration for half-maximal effect: 117 uM
Compound 4: the middle estimate sits 2.0-fold (0.29 log units) below what was measured; low and high end bracket the measured number.
By their numbers in this assay, from the lowest: compound 1; then compounds 2 and 4 (each within the scatter of the next); then compound 3.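

In this assay, replacing 3-phenylprop-2-en-1-yl with carbamoylmethyl gives a 29-fold higher number from compound 1 to compound 4 (1.47 log units; beyond the scatter), and this is the first step shown in which only this one group changes. It shows that the group on this saturated chain carbon bound to an aromatic nitrogen can shift the number substantially on its own, with the rest of the molecule held the same. The change is a bundle, however: the six-membered aromatic ring of carbon only leaves, the group goes from 8 heavy atoms to 3, and a hydrogen-bond donor and a hydrogen-bond acceptor enter, while no measurement available here explains the rise in the number.

The compounds shown leave open which part of this bundle carries the step: a benzyl group or a 3-phenylpropyl chain on the same nitrogen would separate the ring from the chain and its double bond, while an amine or a carboxylic acid in place of the carbamoyl would probe the other end. Going by these compounds, whether the step keeps its size on a different core, such as that of compound 3, also remains open.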